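This account rests on a few compounds, and the source may have more. Where it says the series, first, only, none or still open, it means among the compounds named here.

Working notes on the series. Compound 1 `O=C(/C(=C\c1ccc(I)cc1)S(=O)(=O)c1ccc(Br)cc1)c1ccc(Br)cc1` gives 1000 nM in a functional assay on DU-145 cells (Homo sapiens) for inhibition, read by trypan blue exclusion, with a stated time of 96 h; on this read-out lower numbers stand for stronger inhibition of growth and higher numbers for weaker inhibition of growth. Compound 2 `O=C(O)c1ccc(C(=O)/C(=C\c2ccc(O)c(Br)c2)SCc2ccc(Br)cc2)cc1` gives 25000 nM in this assay, the higher of the two numbers; the gap to compound 1 lies beyond the usual scatter. Compound 3 `COc1cc(/C=C(\C(=O)c2ccc(Cl)cc2)S(=O)(=O)Cc2ccccc2Cl)cc(OC)c1` returns only a limit in this assay, > 100000 nM, which is the reporting ceiling (the limit of > 100000 nM in this assay, at which 1 of the 3 values shown sits). Compound 4 `CN1CCN(/C=C(/SCc2ccc(Br)cc2)C(=O)c2ccc(C(=O)O)cc2)CC1[N+](=O)[O-]` is not yet measured; it differs from compound 2 in one place: 4-methyl-3-nitropiperazin-1-yl in place of 3-bromo-4-hydroxyphenyl on a double-bonded chain carbon bound to a double-bonded chain carbon. Within the data shown here, no measured pair shows a change of this kind, so the expectation rests on the structural change alone; the step is expected to go toward weaker inhibition, by about a 2.4-fold higher number from compound 2 to compound 4 (0.38 log units; beyond the scatter). Compound 4 is therefore estimated at 60000 nM, with a range of 15000 nM to 200000 nM, and a real chance that only a limit is reported.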

Compound 4, concentration for 50% growth inhibition: 10000 nM
Estimate against measurement, compound 4: 6.0-fold (0.78 log units) above; measured number outside the range, below it.
By their numbers in this assay, from the lowest: compound 1; then compound 4; then compound 2. At a limit, above all of these: compound 3.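

In this assay this place, on a double-bonded chain carbon bound to a double-bonded chain carbon, accepts a non-aromatic ring: 4-methyl-3-nitropiperazin-1-yl in place of 3-bromo-4-hydroxyphenyl gives a 2.5-fold lower number from compound 2 to compound 4 (0.40 log units; beyond the scatter), a modest step. In this pair, then, the aromatic ring with its bromine and hydroxyl is not needed to hold growth inhibition at this place. Nothing measured on these compounds gives a reason for the step.

Still open, from the compounds shown here alone, is which part of the entering group carries the step. An unsubstituted piperazin-1-yl or a morpholin-4-yl at this place would separate the ring from its methyl and nitro groups.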